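The source may hold more compounds than are shown below. What is called first, only, known or untested is meant among the compounds shown, and "the series" means these compounds.

Measured so far:
compound 1 `CCOc1cc(CN2CCC(NC(=O)c3ccc(NC)nc3)CC2)cc(OCC)c1F` gives 2.66
compound 2 `CCOc1cc(CN2CCC(NC(=O)c3ccc(NC)nc3)CC2)cc(OCC)c1-c1ccc(F)cc1` gives 3.83
compound 3 `CCOc1cc(CN2CCC(NC(=O)c3cncc(C)c3)CC2)ccc1C` gives 3.03

In a physicochemical assay for lipophilicity, read by spectrophotometry, measured as octanol-water partition, at pH 7.4 (on this read-out lower numbers stand for lower lipophilicity and higher numbers for higher lipophilicity), compound 1 holds the lowest of these three numbers. Compound 4 `CCOc1cc(CN2CCC(NC(=O)c3ccc(NC(C)C)nc3)CC2)cc(OCC)c1F` carries one change from compound 1: isopropyl in place of methyl on a nitrogen on an aromatic ring in words, isopropyl in place of methyl on a nitrogen on an aromatic ring. For the measured compounds named here, no measured step touches that nitrogen. Going by the values given here, the only step available, a 4-fluorophenyl in place of fluoro on an aromatic carbon, shows a number 1.17 log units higher from compound 1 to compound 2 (beyond the scatter) at another place, so it bears only loosely. From it, a smaller upward step is expected here, namely a number 0.64 log units higher from compound 1 to compound 4 (beyond the scatter) in this assay. For compound 4 the estimated value is 3.3 within an expected range from 2.9 to 3.7 in this assay.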

Compound 4, distribution coefficient: 3.39
The estimate for compound 4 lay 0.09 log units below the measured number; low and high end bracket the measured number.
By their numbers in this assay, from the lowest: compound 1; then compound 3; then compound 4; then compound 2.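

Isopropyl in place of methyl on a nitrogen on an aromatic ring gives, in this assay, a number 0.73 log units higher from compound 1 to compound 4 (beyond the scatter). For the compounds shown here, this shows that the read-out also responds at this nitrogen, which no earlier step touched, to a change that brings in only carbon, with no ring, hydrogen-bond donor or hydrogen-bond acceptor. Nothing available here accounts for the size of this step.

The compounds shown leave open how an ethyl group, a cyclopropyl group or a plain amine at this nitrogen would read. They also leave open whether the same step would hold with the 4-fluorophenyl group of compound 2 in place.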